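Swapping an Aryl Sulfonamide for a Chlorothiophene Amide

The compounds below may be only part of what the source reports. "The series", "measured", "known", "first", "only" and "open" are said of these compounds alone.

The account begins with three measured compounds. Compound 1 `O=C(Nc1ccc(Sc2nc3ccccc3s2)cc1)c1cc(Br)cc(Br)c1O` was tested in an ADME assay on FHC cells (Homo sapiens) for cytotoxicity, read by resazurin assay, with a stated time of 48 h (a lower number here means that less compound is tolerated, a higher number that more compound is tolerated), where compound 1 gives 74000 nM. Compound 2 `COc1c(Br)cccc1C(=O)Nc1ccc(Sc2nc3ccccc3s2)c(Cl)c1` is known in this assay only as a limit, and compound 2 gives > 100000 nM. Compound 3 `COc1ccc(S(=O)(=O)Nc2ccc3oc(-c4ccc(NS(=O)(=O)c5cc(F)ccc5OC)cc4)nc3c2)cc1` is likewise known only as a limit, and compound 3 gives > 100000 nM. Among the compounds with values here, compound 3 therefore stands at the limit of > 100000 nM in this assay, at which 2 of the 3 values shown sit, so nothing more than that limit is known of it, and no step between two measured compounds is available to guide what follows.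

The compound still to be measured is compound 4 `COc1ccc(S(=O)(=O)Nc2ccc3oc(-c4ccc(NC(=O)c5ccc(Cl)s5)cc4)nc3c2)cc1`. It differs from compound 3 at one place: a group of 8 heavy atoms (5 carbon, 1 oxygen, 1 sulfur, 1 chlorine; one five-membered aromatic ring with 1 hetero atom) in place of a group of 12 heavy atoms (7 carbon, 3 oxygen, 1 fluorine, 1 sulfur; one six-membered aromatic ring of carbon only), on a nitrogen on an aromatic ring. A (5-chlorothiophen-2-yl)carbonyl group enters on a nitrogen on an aromatic ring in place of the larger group built around one six-membered aromatic ring of carbon only.

Since only a limit exists for compound 3, the step from compound 3 to compound 4 in this assay is expected to be an at least 1.1-fold lower number from compound 3 to compound 4 (0.04 log units; that floor lies within the scatter), a modest one in either direction and possibly none beyond the scatter. Compound 4 is estimated to give 90000 nM, with a range from 35000 nM to 200000 nM.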

Compound 4, half-maximal cytotoxic concentration: > 100000 nM
Compound 4 gave a limit, no number (the forecaster's own chance of this, stated with the estimate: 55%); middle value at least 1.1-fold (0.04 log units) from the limit.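

Within the data shown here, compound 3 and compound 4 are both known only as limits in this assay, so no step between them can be read: the limit of > 100000 nM in this assay, at which 3 of the 4 values shown sit. The compounds shown leave open what number either compound would give, and so whether the (5-chlorothiophen-2-yl)carbonyl group changes this read-out at all.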